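A few compounds are considered here, and "the series" means these few. Any claim that something is new, unique, unknown or untested is made for them only; others in the source may bear on it.

Compound 1 `COc1ccc2cc(C(C)c3nnc4n3N=C(c3ccc(C)cc3)CS4)ccc2c1` and compound 2 `CC(c1ccc(-c2ccccc2)c(F)c1)c1nnc2n1N=C(c1ccc(Cl)cc1Cl)CS2` share a core and differ at both of its ends. In a functional assay on MCF7 cells (Homo sapiens) for inhibition, read by sulforhodamine B assay, with a stated time of 72 h (a higher number here means a weaker inhibitor, a lower number a stronger inhibitor), compound 1 gives 11000 nM, and in this assay compound 2 gives 7600 nM. The two numbers lie within the usual scatter of each other, so neither compound can be called the stronger inhibitor, and compound 1 cannot be set apart from compound 2 on these numbers alone.

Compound 3 `COc1ccc2cc(C(C)c3nnc4n3N=C(c3ccc(OC(F)(F)F)cc3)CS4)ccc2c1` has not yet been measured. It differs from compound 1 in one place: trifluoromethoxy in place of methyl on an aromatic carbon. For the measured compounds named here, no measured pair in this set shows what this change does, so the expectation can rest only on the change itself and on where compound 1 stands. The step of a 1.2-fold lower number from compound 1 to compound 3 (0.09 log units; within the scatter) is expected to be small, without a clear direction, and not beyond the scatter, because compound 1 gives 11000 nM and nothing in the measured numbers points away from that level. Compound 3 is therefore expected to give about 9000 nM in this assay, with a range from 3000 nM to 27000 nM.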

Compound 3, half-maximal inhibitory concentration: 8800 nM
The estimate for compound 3 lay 1.0-fold (0.01 log units) above the measured number; low and high end bracket the measured number.
By their numbers in this assay, from the lowest: compounds 2, 3 and 1 (each within the scatter of the next).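

In this assay, putting trifluoromethoxy in place of methyl on an aromatic carbon, para to a large group, gives a 1.3-fold lower number from compound 1 to compound 3 (0.10 log units; within the scatter). For the compounds shown here, this is the first pair here that differs in only one place, so the comparison can be tied to a single change, unlike the comparison of compounds that differ at both ends of the shared core. It shows that, in this assay, a group of five heavy atoms, including oxygen and fluorine, can take the place of a one-carbon methyl at this position without a difference that can be told apart from the scatter, and no supporting measurement is available to explain this result.

As far as these compounds go, it remains open whether this position is generally tolerant or whether methyl and trifluoromethoxy simply happen to give similar numbers, and an amine, a carboxylic acid or a longer alkyl chain on the same carbon could help to tell these cases apart. From the compounds shown here alone, it is also open whether the same exchange would give a similar result with a different group at the other end of the core.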